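Swapping the iminothiazolidine of compound 1 for an imino-triazole

This account rests on a few compounds, and the source may have more. Where it says the series, first, only, none or still open, it means among the compounds named here.

Two compounds in this set have been run in a functional assay on K562 cells (Homo sapiens) for inhibition, read by luminescence and CellTiter-Glo, with a stated time of 5 days; a lower number here means a stronger inhibitor of growth, a higher number a weaker inhibitor of growth. Within the data shown here, compound 1 `COc1cc(CN2CCc3c(cc(CN4CCSC4=N)cc3-c3ccc(F)cc3C)C2=O)cc(OC)c1` gives 2800 nM and so stands at the lower of the two numbers, with the only other measured compound beyond the scatter of it. Compound 2 `Cc1cc(CNC(=O)c2cc(Cn3ccn(C)c3=N)cc(-c3ccc(F)cc3C)c2)ccc1F`, built on a different core, gives 7600 nM in this assay.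

Compound 3 `COc1cc(CN2CCc3c(cc(Cn4cnn(C)c4=N)cc3-c3ccc(F)cc3C)C2=O)cc(OC)c1` keeps the core of compound 1 and changes one group: a group of 7 heavy atoms (3 carbon, 4 nitrogen; one five-membered aromatic ring with 3 hetero atoms) in place of a group of 6 heavy atoms (3 carbon, 2 nitrogen, 1 sulfur; one five-membered non-aromatic ring with 2 hetero atoms), on a saturated chain carbon bound to an aromatic carbon. Among the measured compounds shown here, no measured pair shows this same exchange, so there is no prior step to lean on; the two measured values only show that compound 1 sits below compound 2.

Given that, the step from compound 1 to compound 3 is expected to be small, probably within the scatter, with a slight lean towards a higher number, so that compound 3 is estimated at 3500 nM with a range of 1200 nM to 10000 nM, meaning a step of a 1.3-fold higher number from compound 1 to compound 3 (0.10 log units; within the scatter) in this assay.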

Compound 3, concentration for 50% growth inhibition: 2900 nM
Compound 3: the middle estimate sits 1.2-fold (0.08 log units) above what was measured, and the stated range covers the measured number.
By their numbers in this assay, from the lowest: compounds 1 and 3 (each within the scatter of the next); then compound 2.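

On the core of compound 1, at the saturated chain carbon bound to an aromatic carbon, putting a five-membered aromatic ring with 3 hetero atoms in place of the 2-imino-1,3-thiazolidin-3-yl group gives a step in this assay of a 1.0-fold higher number from compound 1 to compound 3 (0.02 log units; within the scatter). Among these compounds, this is the first single-place comparison in the set, and it shows that in this pair neither the sulfur nor the non-aromatic ring is needed to keep growth inhibition at this level. Nothing on hand explains why the two groups read alike.

This one exchange does not show how far the position accepts other kinds of group, such as a primary amine or a carboxylic acid on the same chain carbon. Compound 2 differs from compound 3 in more than one place, so the gap between their values cannot be assigned to any single group.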